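From a benzofuranyl limit to a pyridinylmethoxy ether

The source may hold more compounds than are shown below. What is called first, only, known or untested is meant among the compounds shown, and "the series" means these compounds.

Measured in an assay on CHO cells for displacement of a labelled ligand from prostaglandin E2 receptor EP3 subtype (Mus musculus), read by scintillation counting, with a stated time of 60 min; on this read-out higher numbers stand for weaker inhibition and lower numbers for stronger inhibition:
compound 1 `O=C(O)CCCSCCN1C(=O)CC[C@@H]1/C=C/[C@@H](O)Cc1cccc(N2Cc3ccccc3C2)c1`: > 10000 nM
compound 2 `O=C(O)CCCSCCN1C(=O)CC[C@@H]1/C=C/[C@@H](O)Cc1cccc(-c2cc3ccccc3o2)c1`: > 10000 nM

Compound 1 and compound 2 share one core and differ in a single place. In this assay compound 1 gives > 10000 nM, which is a limit of the assay and not a number. In this assay compound 2 likewise gives > 10000 nM, again a limit. Going by the values given here, the only measured step, a step that the two limits leave unreadable from compound 1 to compound 2, therefore has no readable size, and compound 2 stands at the limit together with the one other value shown, as the limit of > 10000 nM in this assay, at which 2 of the 2 values shown sit, records.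

Compound 3 `O=C(O)CCCSCCN1C(=O)CC[C@@H]1/C=C/[C@@H](O)Cc1cccc(OCc2ccncc2)c1` is not yet measured. It differs from compound 2 by (pyridin-4-yl)methoxy in place of 1-benzofuran-2-yl on an aromatic carbon. Among the compounds with values here, no measured step has a readable size that bears on this change; the one step available is unreadable, so no direction or size of change in this assay can be taken from it. The expectation for compound 3 is that this assay again returns only a limit, with the step that the limit leaves unreadable from compound 2 to compound 3 estimated as essentially none beyond the scatter. Compound 3 is thus expected at about 15000 nM, within 3000 nM to 60000 nM.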

Compound 3, inhibition constant: > 10000 nM
Compound 3 gave a limit, no number; the forecaster's own chance of this, stated with the estimate: 75%; the middle value lies beyond the limit too.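

In this assay compound 3 gives > 10000 nM as a limit of the assay and not a number. The steps from compound 1 and compound 2 to compound 3 therefore cannot be read, and all three compounds stand together: the limit of > 10000 nM in this assay, at which 3 of the 3 values shown sit. The compounds shown leave open which group at this place, if any, would give a measurable inhibition constant.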